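The compounds below may be only part of what the source reports. "The series", "measured", "known", "first", "only" and "open" are said of these compounds alone.

In a functional assay on MCF7 cells (Homo sapiens) for antiproliferative activity, read by sulforhodamine B assay, with a stated time of 72 h (a higher number here means a weaker inhibitor, a lower number a stronger inhibitor), compound 3 (`Cc1cc(NS(=O)(=O)c2ccc(Nc3nncc4ccccc34)cc2)no1`) gives 46 nM as the highest of three numbers, with compound 1 (`Cc1cc(C)nc(NS(=O)(=O)c2ccc(Nc3nncc4ccccc34)cc2)n1`) at 7.7 nM and compound 2 (`Fc1ccc(Nc2nncc3ccccc23)cc1`) at 3.5 nM below it. Compound 4 (`NS(=O)(=O)c1ccc(Nc2nncc3ccccc23)cc1`) carries hydrogen in place of 5-methyl-1,2-oxazol-3-yl on a sulfonamide nitrogen. Among the measured compounds shown here, one measured step bears on this change, a modest one at that same kind of nitrogen (a 6.0-fold higher number from compound 1 to compound 3 (0.78 log units; beyond the scatter)). For the measured compounds named here, no measured compound carries hydrogen there, so the direction is uncertain, but with compound 3 at the top (46 nM) a step of similar or smaller size toward a lower number is expected. The expected change in this assay is a 2.3-fold lower number from compound 3 to compound 4 (0.36 log units; beyond the scatter) as a rough estimate. Compound 4 is estimated at 20 nM (expected range 4 nM to 100 nM).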

Compound 4, half-maximal inhibitory concentration: 37 nM
Compound 4: middle estimate off by 1.9-fold (0.27 log units), on the low side; measured number inside the range.
By their numbers in this assay, from the lowest: compound 2; then compound 1; then compounds 4 and 3 (each within the scatter of the next).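

Under this assay the bare sulfonamide of compound 4 matches the 5-methyl-1,2-oxazol-3-yl compound (a 1.2-fold lower number from compound 3 to compound 4 (0.09 log units; within the scatter)), so at this nitrogen that ring and hydrogen cannot be told apart. The 4,6-dimethylpyrimidin-2-yl group does stand apart from hydrogen (a 4.8-fold higher number from compound 1 to compound 4 (0.68 log units; beyond the scatter)), and the unsubstituted sulfamoyl group also stands apart from fluoro (an 11-fold higher number from compound 2 to compound 4 (1.02 log units; beyond the scatter)). Nothing available explains these differences. Open, going by these compounds, is whether a small group such as methyl or acetyl on this nitrogen would track hydrogen or the pyrimidine. Also open, on these data alone, is how an amine or a carboxylic acid would read in place of fluoro.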